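The source may hold more compounds than are shown below. What is called first, only, known or untested is meant among the compounds shown, and "the series" means these compounds.

Compound 1 `NS(=O)(=O)c1ccc(/C=C/c2ccc(O)c(O)c2)cc1`: 29100 nM
Compound 2 `NS(=O)(=O)c1ccc(/C=C/c2ccc(F)cc2)cc1`: 36300 nM

The measure here is a functional assay on CAKI-1 cells (Homo sapiens) for inhibition; on this read-out lower numbers stand for stronger inhibition of growth and higher numbers for weaker inhibition of growth. On this scale compound 2 gives 36300 nM, which stands level with compound 1, since the two values lie within the usual scatter of repeated measurements.

The next compound to consider is compound 3 `NS(=O)(=O)c1ccc(/C=C/c2ccc(O)cc2)cc1`. It has hydroxy in place of fluoro on an aromatic carbon, para to a large group: hydroxy in place of fluoro on an aromatic carbon. Within the data shown here, no measured pair shows this exact change on its own, so any forecast rests on indirect evidence. Compound 1 also carries hydroxy, and it gives 29100 nM, close to compound 2. Two compounds are thin support, but they suggest no large move in either direction.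

The expected change is a 1.2-fold lower number from compound 2 to compound 3 (0.08 log units; within the scatter), which would not go beyond the scatter. The estimate for compound 3 is 30000 nM, with an expected range from 12000 nM to 70000 nM.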

Compound 3, concentration for 50% growth inhibition: 5590 nM
Beside the measured number, compound 3's estimate is 5.4-fold (0.73 log units) above it; measured number below the stated range.
By their numbers in this assay, from the lowest: compound 3; then compounds 1 and 2 (each within the scatter of the next).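

In this assay, hydroxy in place of fluoro on an aromatic carbon, para to a large group, gives a 6.5-fold lower number from compound 2 to compound 3 (0.81 log units; beyond the scatter) and so shows that this position responds to the change, which compound 1 and compound 2, level with each other, could not reveal. Hydrogen in place of hydroxy on an aromatic carbon gives a 5.2-fold lower number from compound 1 to compound 3 (0.72 log units; beyond the scatter) and so shows that the extra hydroxy of compound 1 does not simply add to the effect, leaving compound 3 with the lowest number of the three. Among these compounds, nothing measured here explains why this single change moves the number so far.

Still open, on these data alone, is whether hydroxy is special at this place, since a methoxy group or an amine there would test that. Plain hydrogen at this place would show what fluoro and hydroxy each contribute.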